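Dimethylphenyl isomers on a triazole across two aminochromene cores

The compounds below may be only part of what the source reports. "The series", "measured", "known", "first", "only" and "open" are said of these compounds alone.

Measured compounds:
Compound 1 `Cc1ccc(C)c(-n2nncc2CN2C(=O)C3(C(C#N)=C(N)Oc4c3c3nc5ccccc5nc3c3ccccc43)c3ccccc32)c1`: > 50000 nM
Compound 2 `Cc1cc(C)cc(-n2nncc2CN2C(=O)C3(C(C#N)=C(N)Oc4c3c3nc5ccccc5nc3c3ccccc43)c3ccccc32)c1`: > 50000 nM
Compound 3 `Cc1ccc(C)c(-n2nncc2CN2C(=O)C3(C(C#N)=C(N)Oc4c(N)cc5nc6ccccc6nc5c43)c3ccccc32)c1`: > 50000 nM

Compounds 1, 2 and 3 were tested in a functional assay on A549 cells (Homo sapiens) for antiproliferative activity, read by MTT assay, with a stated time of 48 h; on this read-out higher numbers stand for weaker inhibition and lower numbers for stronger inhibition. In this assay compound 1 returns only a limit, > 50000 nM, and not a number. Compound 2 likewise returns only a limit, > 50000 nM. Compound 3 as well returns only a limit, > 50000 nM. All three values therefore sit at the limit of > 50000 nM in this assay, at which 3 of the 3 values shown sit, and none of them is a measured figure.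

Compounds 1 and 2 share a core and differ in one place: 3,5-dimethylphenyl in place of 2,5-dimethylphenyl on an aromatic nitrogen. The step between them, a step that the two limits leave unreadable from compound 1 to compound 2, cannot be read, since both ends are limits. Compound 3 carries a different core; the difference between the core of compound 1 and the core of compound 3 is not broken down here.

Compound 4 `Cc1cc(C)cc(-n2nncc2CN2C(=O)C3(C(C#N)=C(N)Oc4c(N)cc5nc6ccccc6nc5c43)c3ccccc32)c1` has not yet been measured in this assay. It stands to compound 3 exactly as compound 2 stands to compound 1: 3,5-dimethylphenyl in place of 2,5-dimethylphenyl on an aromatic nitrogen. Both changes are the same change, made at the same place.

Since compound 1 gives > 50000 nM and compound 2 gives > 50000 nM, the earlier instance of this change left both ends at the limit, and compound 3 gives > 50000 nM as a starting point; so compound 4 is expected to give 80000 nM, most likely again reported as a limit, and the expected step is a step that the limit leaves unreadable from compound 3 to compound 4. The expected range for compound 4 is from 30000 nM to 300000 nM.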

Compound 4, half-maximal inhibitory concentration: 31200 nM
Compound 4: middle estimate off by 2.6-fold (0.41 log units), on the high side, within the range that was stated.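

On the core of compound 3, 3,5-dimethylphenyl in place of 2,5-dimethylphenyl gives in this assay an at least 1.6-fold lower number from compound 3 to compound 4 (0.20 log units; that floor lies within the scatter), so the change is readable on this core only as a floor, and that floor alone does not establish a real difference. On the core of compound 1 the same change cannot be read, since compound 1 and compound 2 both end at a limit, so the series does not show that the change carries from one core to the other, nor that it fails to carry. Among these compounds, compound 4, at 31200 nM, is the only compound of the four with a number. The other three are not measured figures: the limit of > 50000 nM in this assay, at which 3 of the 4 values shown sit.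

As far as these compounds go, the size of the change on either core therefore stays open, as does whether the core of compound 3 differs in any real way from the core of compound 1. Also open, from the compounds shown here alone, is how either core would read with a carboxylic acid or a dimethylamino group in place of the methyl groups on the phenyl ring, or with a longer chain in place of the methylene link to the five-membered ring.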